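The source may report more compounds than this note shows. Statements on the series, on what has been measured and on what is new or still open speak of the compounds shown alone.

Three compounds sharing one core have numbers in a functional assay on KMS-11 cells (Homo sapiens) for antiproliferative activity, read by CellTiter-Glo, with a stated time of 72 h; on this read-out lower numbers stand for stronger inhibition and higher numbers for weaker inhibition: compound 1 (`COc1ccc(C(=O)N(Cc2ccncc2)Cc2cccc(OCCc3ccc(C)cc3)c2)cc1`) gives 9100 nM, compound 2 (`COc1ccc(C(=O)N(Cc2ccncc2)Cc2cccc(OCC3CCOCC3)c2)cc1`) gives 17700 nM and compound 3 (`COc1ccc(C(=O)N(Cc2ccncc2)Cc2cccc(OCC(=O)c3ccc(Cl)cc3)c2)cc1`) gives 18500 nM. For compound 3, the gap to the nearest value is flat, a 1.0-fold higher number from compound 2 to compound 3 (0.02 log units; within the scatter), and the gap to the furthest is modest, a 2.0-fold higher number from compound 1 to compound 3 (0.31 log units; beyond the scatter). The remaining pair shows a 1.9-fold higher number from compound 1 to compound 2 (0.29 log units; within the scatter).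

Compound 4 (`COc1ccc(C(=O)N(Cc2ccncc2)Cc2cccc(OCC(=O)c3cccc(Br)c3)c2)cc1`) differs from compound 3 in one place, on a carbonyl carbon: 3-bromophenyl in place of 4-chlorophenyl on a carbonyl carbon. Among the compounds with values here, no measured step changes this group alone, so the series offers no direct precedent. The nearest evidence comes from replacements on a saturated chain carbon bound to an oxygen on an aromatic ring, and these stayed small. The largest of them is the modest one already noted, and the other two lie within the scatter.

In this assay, no step beyond the scatter is therefore expected, and no direction is favoured with any confidence. The anchor for this expectation is compound 3 at 18500 nM. The expected change is small: a 1.2-fold lower number from compound 3 to compound 4 (0.06 log units; within the scatter). Compound 4 is estimated at 16000 nM, with an expected range from 8000 nM to 32000 nM.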

Compound 4, half-maximal inhibitory concentration: 18700 nM
Compound 4: middle estimate off by 1.2-fold (0.07 log units), on the low side, and the stated range covers the measured number.
By their numbers in this assay, from the lowest: compounds 1, 2, 3 and 4 (each within the scatter of the next, the first and the last beyond it).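

The first direct read at the carbonyl carbon shows that 3-bromophenyl in place of 4-chlorophenyl gives a 1.0-fold higher number from compound 3 to compound 4 (0.00 log units; within the scatter) in this assay, so this swap, which changes both the halogen and where it sits on the ring, leaves the number flat. The new compound also adds to the picture on the saturated chain carbon bound to an oxygen on an aromatic ring: (3-bromophenyl)carbonyl in place of oxan-4-yl gives a 1.1-fold higher number from compound 2 to compound 4 (0.02 log units; within the scatter), and in place of 4-methylbenzyl it gives a 2.1-fold higher number from compound 1 to compound 4 (0.31 log units; beyond the scatter), a modest step of the same size as a 2.0-fold higher number from compound 1 to compound 3 (0.31 log units; beyond the scatter). No measurement at hand bears on the reason for this flat result.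

With both the halogen and its ring position changing in one step, the compounds shown cannot separate the two, and a 3-chlorophenyl or 4-bromophenyl group would be needed to do so. Also open, as far as these compounds go, is whether this aryl ring tolerates anything other than a halogen, such as an amine or a carboxylic acid, or whether any change here can move the number beyond the scatter.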